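The source may hold more compounds than are shown below. What is called first, only, known or untested is meant among the compounds shown, and "the series" means these compounds.

Measured in a functional assay on SGC-7901 cells (Homo sapiens) for antiproliferative activity, read by MTT assay, with a stated time of 48 h; on this read-out lower numbers stand for stronger inhibition and higher numbers for weaker inhibition:
- compound 1 `Fc1ccccc1-c1nnc(SCc2ccc(Cl)nc2)o1`: 9.12 ug/mL
- compound 2 `Clc1ccc(-c2nnc(SCc3ccc(Cl)nc3)o2)cc1`: 8.62 ug/mL

Compound 2, at 8.62 ug/mL, lies within the scatter of compound 1, so the two cannot be ranked. Compound 3 `Clc1ccc(CSc2nnc(-c3ccccn3)o2)cn1` has not yet been measured in this assay. It differs from compound 2 by one change: pyridin-2-yl in place of 4-chlorophenyl on an aromatic carbon. Within the data shown here, only one measured step bears on this: a 1.1-fold lower number from compound 1 to compound 2 (0.02 log units; within the scatter), which also exchanges one aromatic group for another and stays within the scatter. Among the measured compounds shown here, no measured compound carries pyridin-2-yl, so that step is only a loose guide. No step beyond the scatter is therefore expected, and no firm direction can be given. The estimated step is a 1.1-fold higher number from compound 2 to compound 3 (0.04 log units; within the scatter). Compound 3 is expected at about 9.5 ug/mL, with an estimated range of 4 ug/mL to 23 ug/mL.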

Compound 3, half-maximal inhibitory concentration: 12.6 ug/mL
Compound 3: middle estimate off by 1.3-fold (0.12 log units), on the low side; the range from low to high includes it.
By their numbers in this assay, from the lowest: compounds 2, 1 and 3 (each within the scatter of the next).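

In this assay, among these compounds, this place on the five-membered aromatic ring now carries a six-membered aromatic ring with a hetero atom and a hydrogen-bond acceptor, whereas the earlier compounds carried only rings of carbon. Neither a 1.5-fold higher number from compound 2 to compound 3 (0.16 log units; within the scatter) nor a 1.4-fold higher number from compound 1 to compound 3 (0.14 log units; within the scatter) lies beyond the scatter, so pyridin-2-yl cannot be told apart from 4-chlorophenyl or from 2-fluorophenyl here, and the three groups read alike. Nothing at hand offers an explanation for these numbers.

As far as these compounds go, whether an amine or a carboxylic acid at this place would move the number beyond the scatter remains open. So does the effect of changing the group of 9 heavy atoms on the same five-membered ring, which stays the same in all three compounds.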